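The source may report more compounds than this note shows. Statements on the series, on what has been measured and on what is new or still open speak of the compounds shown alone.

Compound 1 `COc1ccc2nc(NC(=O)c3cn(-c4ccccc4)nc3-c3ccccc3)sc2c1`: 40600 nM
Compound 2 `Cc1ccc2nc(NC(=O)c3cn(-c4ccccc4)nc3-c3ccccc3)sc2c1`: 23200 nM

Both were tested in a functional assay on U-87MG ATCC cells for cytotoxicity against U-87 MG (Homo sapiens), read by MTT assay, with a stated time of 72 h; a lower number here means a stronger inhibitor, a higher number a weaker inhibitor. Within the data shown here, compound 1 gives the higher of the two numbers, with compound 2 as its only neighbour. Among the measured compounds shown here, the single measured step, a 1.8-fold lower number from compound 1 to compound 2 (0.24 log units; within the scatter), stays within the scatter. Compound 3 `COc1ccc2nc(NC(=O)c3cn(-c4ccccc4)nc3-c3ccc(F)cc3)sc2c1` differs from compound 1 by fluoro in place of hydrogen on an aromatic carbon. For the measured compounds named here, no measured step touches that position, so there is nothing direct to draw on, and the one known step is small. Relative to compound 1, compound 3 is therefore expected to differ by a 1.2-fold lower number from compound 1 to compound 3 (0.06 log units; within the scatter). The estimate for compound 3 in this assay is 35000 nM, expected between 15000 nM and 80000 nM.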

Compound 3, half-maximal inhibitory concentration: > 50000 nM
Compound 3: no number, only a limit; the forecaster's own chance of this, stated with the estimate: 10%; middle value at least 1.4-fold (0.15 log units) from the limit.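

Going from phenyl to 4-fluorophenyl, a change at a place the earlier step did not touch, gives no sign of a stronger inhibitor in this assay. Compound 3 reaches only a limit of the assay, not a number: the limit of > 50000 nM in this assay, at which 1 of the 3 values shown sits. The step therefore has only a floor, an at least 1.2-fold higher number from compound 1 to compound 3 (0.09 log units; that floor lies within the scatter), so the true gap could be small or much larger.

As far as these compounds go, whether chloro, an amine or a carboxylic acid in place of fluoro would give a readable number remains open. So does whether fluoro behaves the same way alongside the methyl of compound 2.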